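Two Limits and a Change at the Aryl Amine

The source may report more compounds than this note shows. Statements on the series, on what has been measured and on what is new or still open speak of the compounds shown alone.

Compound 1, `O=C(Nc1ccccc1)Nc1ccc2ncnc(Nc3cccc(C(F)(F)F)c3)c2c1`: in a functional assay on A549 cells (Homo sapiens) for antiproliferative activity, read by MTT assay, with a stated time of 72 h (on this read-out lower numbers stand for stronger inhibition and higher numbers for weaker inhibition), compound 1 gives > 10000 nM, which is a limit of the assay and not a number.
Compound 2, `CN1CCN(CCNC(=O)Nc2ccc3ncnc(Nc4cccc(C(F)(F)F)c4)c3c2)CC1`: in this assay compound 2 gives > 10000 nM, again only a limit.

Compound 2 therefore stands at the assay limit, with no numerical value known; both measured values sit there, as the limit of > 10000 nM in this assay, at which 2 of the 2 values shown sit, records. Within the data shown here, the one measured step, a step that the two limits leave unreadable from compound 1 to compound 2, passes between two limits and cannot be read in size or direction.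

Compound 3, `C[C@@H](Nc1ncnc2ccc(NC(=O)NCCN3CCN(C)CC3)cc12)c1ccccc1`, differs from compound 2 by 1-phenylethyl in place of 3-(trifluoromethyl)phenyl on a nitrogen on an aromatic ring. Among the measured compounds shown here, no measured step touches this nitrogen; the only step available, a step that the two limits leave unreadable from compound 1 to compound 2, concerns an amide-type nitrogen elsewhere and is itself unreadable. Nothing in the data therefore fixes a direction or a size for the expected step of an at least 1.2-fold lower number from compound 2 to compound 3 (0.09 log units; that floor lies within the scatter), and the expectation leans only on the limit shown for compound 2. Compound 3 is accordingly estimated to give 8000 nM, within a wide range from 1000 nM to 50000 nM, with a fair chance that only a limit is reported again.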

Compound 3, half-maximal inhibitory concentration: > 10000 nM
Compound 3: a limit, no number; the forecaster's own chance of this, stated with the estimate: 55%; at least 1.2-fold (0.09 log units) between middle value and limit.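

In this assay, among these compounds, compound 3 gives > 10000 nM, again a limit and not a number, so no step from compound 2 to compound 3 can be read. The compounds shown leave open whether either change, at the amide-type nitrogen or at the nitrogen on an aromatic ring, alters activity, as they offer only one reading: the limit of > 10000 nM in this assay, at which 3 of the 3 values shown sit.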